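The compounds below may be only part of what the source reports. "The series", "measured", "known", "first", "only" and "open" are said of these compounds alone.

The measured compounds:

Compound 1 `Cc1nc(N)c2c(-c3ccco3)cn([C@@H]3O[C@H](CO)[C@@H](O)[C@H]3O)c2n1`: in a functional assay on HCT-116 cells (Homo sapiens), read by MTT assay, with a stated time of 72 h (a lower number here means a stronger inhibitor, a higher number a weaker inhibitor), compound 1 gives > 20000 nM, which is a limit of the assay and not a number.

Compound 2 `Cc1nc(N)c2c(-c3cc4ccccc4o3)cn([C@@H]3O[C@H](CO)[C@@H](O)[C@H]3O)c2n1`: in this assay compound 2 gives > 20000 nM, again a limit.

Compound 3 `CNc1ncnc2c1c(-c1cc3ccccc3o1)cn2[C@@H]1O[C@H](CO)[C@@H](O)[C@H]1O`: in this assay compound 3 gives > 20000 nM, also a limit.

Compounds 2 and 1 share one core and differ in a single place: furan-2-yl in place of 1-benzofuran-2-yl on an aromatic carbon. The step between them is a step that the two limits leave unreadable from compound 2 to compound 1, so the two limits leave its size unreadable. Compound 3 carries the same 1-benzofuran-2-yl group as compound 2 but sits on a different core; the two have the same atoms joined differently, and the difference between the cores is not broken down here.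

Compound 4 `CNc1ncnc2c1c(-c1ccco1)cn2[C@@H]1O[C@H](CO)[C@@H](O)[C@H]1O` stands to compound 3 as compound 1 stands to compound 2: furan-2-yl in place of 1-benzofuran-2-yl on an aromatic carbon. The surroundings of the change are described in the same words for both pairs, so this is the same change made on the other core.

Within the data shown here, the one thing the measurements show is the limit of > 20000 nM in this assay, at which 3 of the 3 values shown sit. No readable step exists anywhere in this set, and nothing marks the furan-2-yl group or the benzofuran-2-yl group as different in this assay.

For the step from compound 3 to compound 4 a size of about a step that the limit leaves unreadable from compound 3 to compound 4 is expected, resting on the unreadable step that the two limits leave unreadable from compound 2 to compound 1 made by the same change. That expectation also rests on compound 3, whose value > 20000 nM is a limit. Compound 4 is therefore estimated at 30000 nM, expected to lie between 12000 nM and 100000 nM, and most likely to be reported only as a limit once more.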

Compound 4, half-maximal inhibitory concentration: 230 nM
For compound 4 the middle estimate is 130-fold (2.12 log units) above the measured one, outside the stated range (below it).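

In this assay, putting furan-2-yl in place of 1-benzofuran-2-yl on the core of compound 3 gives an at least 86-fold lower number from compound 3 to compound 4 (1.93 log units; beyond the scatter), so on this core the change goes with a large gain in potency, and the true step could be larger still, since the value of compound 3 is a limit. On the core of compound 2, the same change gives a step that cannot be read, so this series holds no pair in which the size of the change can be compared across the two cores, and the shared limit is the reason: the limit of > 20000 nM in this assay, at which 3 of the 4 values shown sit. Compound 1 also carries furan-2-yl and still shows only a limit, so the gain seen on one core cannot be assumed to carry over to the other, although the data do not show that the change has no effect there.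

From the compounds shown here alone, it remains open whether the gain is specific to furan-2-yl or would also appear with another group on the same aromatic carbon, such as thiophen-2-yl or phenyl. Also open, going by these compounds, is which of the differences between the two cores decides whether furan-2-yl gives a measurable value, since compound 1 and compound 4 differ in more than one place.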